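Isopropyl to cyclopentyl on the ketone side chain

The source may hold more compounds than are shown below. What is called first, only, known or untested is meant among the compounds shown, and "the series" means these compounds.

Compound 1: `Cc1c(OCCCCOc2ccc(C(=O)O)cc2Cl)ccc(C(=O)CC2CCCC2)c1O`, 27.4%
Compound 2: `Cc1c(OCCCCOc2cccc(C(=O)O)c2)ccc(C(=O)CC2CCCC2)c1O`, 92.9%
Compound 3: `Cc1ccc(C(=O)O)cc1OCCCCOc1ccc(C(=O)CC(C)C)c(O)c1C`, 29.4%

Of the compounds shown here, three have been measured in an assay on HEK293 cells for positive allosteric modulation of metabotropic glutamate receptor 3 (Rattus norvegicus), read by thallium flux, with a stated time of 2.5 min; a lower number here means a smaller maximal response, a higher number a larger maximal response. Compound 3 stands second highest of the three numbers, with compound 1 nearest, lower by a gap that lies within the scatter, and compound 2 furthest, higher by a gap that lies beyond it. Within the data shown here, the one measured step, a number 65.5 percentage points higher from compound 1 to compound 2 (beyond the scatter), concerns the carboxyphenyl end of the chain and not the ketone side chain.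

Compound 4, `Cc1ccc(C(=O)O)cc1OCCCCOc1ccc(C(=O)CC2CCCC2)c(O)c1C`, is not yet measured. It differs from compound 3 in one place: cyclopentyl in place of isopropyl on a saturated chain carbon bound to a carbonyl carbon. Among the measured compounds shown here, no measured step bears directly on this change. Compounds 1 and 2 carry the (cyclopentylmethyl)carbonyl, compound 3 the isobutylcarbonyl, and compound 1, which differs from compound 3 in two places, gives a value within the scatter of compound 3. On that basis compound 4 is expected to show no step beyond the scatter, a number 0.6 percentage points higher from compound 3 to compound 4 (within the scatter), and its value in this assay is estimated at 30%, between 15% and 50%.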

Compound 4, largest response reached (reported as percent of maximum), in percent of the reference or control that the assay uses: 26.9%
Beside the measured number, compound 4's estimate is 3.1 percentage points above it, within the range that was stated.
By their numbers in this assay, from the lowest: compounds 4, 1 and 3 (each within the scatter of the next); then compound 2.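

Read directly for the first time, cyclopentyl in place of isopropyl on a saturated chain carbon bound to a carbonyl carbon gives a number 2.5 percentage points lower from compound 3 to compound 4 (within the scatter) in this assay and so leaves the maximal response unchanged with the 5-carboxy-2-methylphenyl end in place. At the other end of the chain, a single methyl separates compound 2 from compound 4: methyl in place of hydrogen on an aromatic carbon gives a number 66 percentage points lower from compound 2 to compound 4 (beyond the scatter) and thus accounts for a gap as large as the one first seen with the chlorinated acid. Putting 5-carboxy-2-methylphenyl in place of 4-carboxy-2-chlorophenyl on an oxygen on a saturated carbon gives a number 0.5 percentage points lower from compound 1 to compound 4 (within the scatter) so these two ends cannot be told apart here, while the unsubstituted 3-carboxyphenyl of compound 2 stands alone among the four compounds.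

The compounds shown leave open whether the exchange of isopropyl and cyclopentyl would stay equally silent with the 3-carboxyphenyl end of compound 2. They also leave open how a fluorine or a methoxy would compare with the methyl on that ring. Nothing given here explains why the methyl step is so large.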